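The source may report more compounds than this note shows. Statements on the series, on what has been measured and on what is new or still open speak of the compounds shown alone.

Working notes on the series built on the core of compound 1 `O=C(O)/C=C/C(=O)Nc1cccc(-c2nc3ccccc3s2)c1`. In an ADME assay for permeability, using PAMPA (a lower number here means that the compound crosses the layer more slowly, a higher number that the compound crosses the layer faster), compound 1 gives 4 10^-6 cm/s. Compound 2 `CN(C)CCC(=O)Nc1cccc(-c2nc3ccccc3s2)c1` gives 2080 10^-6 cm/s in this assay, and compound 3 `CC(Cl)C(=O)Nc1cccc(-c2nc3ccccc3s2)c1` gives 769 10^-6 cm/s. Compound 3 stands second highest of the three numbers: the step of a 2.7-fold lower number from compound 2 to compound 3 (0.43 log units; beyond the scatter) is modest, whereas a 190-fold higher number from compound 1 to compound 3 (2.28 log units; beyond the scatter) is large.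

Compound 4 `O=C(Nc1cccc(-c2nc3ccccc3s2)c1)c1ccnc(Cl)c1` has not yet been measured in this assay. It differs from compound 3 by 2-chloropyridin-4-yl in place of 1-chloroethyl on a carbonyl carbon. The measured steps at that carbonyl carbon are a 520-fold higher number from compound 1 to compound 2 (2.72 log units; beyond the scatter), a 190-fold higher number from compound 1 to compound 3 (2.28 log units; beyond the scatter) and a 2.7-fold lower number from compound 2 to compound 3 (0.43 log units; beyond the scatter); the two large ones both remove the carboxyethenyl group, which compound 4 does not touch, and none of the three exchanges a chain for an aromatic ring. The step from compound 3 is therefore expected to be a 1.4-fold lower number from compound 3 to compound 4 (0.15 log units; within the scatter), small and if anything downward. Compound 4 is estimated at 550 10^-6 cm/s in this assay, with a range from 220 10^-6 cm/s to 1400 10^-6 cm/s.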

Compound 4, apparent permeability: 478 10^-6 cm/s
Compound 4: the middle estimate sits 1.2-fold (0.06 log units) above what was measured, within the range that was stated.
By their numbers in this assay, from the lowest: compound 1; then compounds 4 and 3 (each within the scatter of the next); then compound 2.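

In this assay, an aromatic ring now stands on the carbonyl carbon, and a 1.6-fold lower number from compound 3 to compound 4 (0.21 log units; within the scatter) shows that 2-chloropyridin-4-yl and 1-chloroethyl cannot be told apart at this position. Against the two other groups the ring gives a 120-fold higher number from compound 1 to compound 4 (2.08 log units; beyond the scatter) and a 4.4-fold lower number from compound 2 to compound 4 (0.64 log units; beyond the scatter), so a six-membered aromatic ring here reads like the chains, and the only large steps at this position remain those that leave 2-carboxyethenyl. Among these compounds, nothing measured so far gives a reason for any of these steps.

Still open, from the compounds shown here alone, is what the ring nitrogen and the chlorine of 2-chloropyridin-4-yl each contribute, which a plain phenyl on the carbonyl carbon would begin to separate. Also open, going by these compounds, is whether the carboxylic acid alone or the acid with its double bond sets the low number of compound 1 at 4 10^-6 cm/s, a question for a saturated 2-carboxyethyl chain.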